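A few compounds are considered here, and "the series" means these few. Any claim that something is new, unique, unknown or untested is made for them only; others in the source may bear on it.

Measured so far in a functional assay on NCI-H460 cells (Homo sapiens) for cytotoxicity, read by MTT assay, with a stated time of 48 h; on this read-out lower numbers stand for stronger inhibition and higher numbers for weaker inhibition:
- compound 1 `COc1cc(/C=C/C(=O)/C=C/c2nc3ccccc3n2C)ccc1O`: 7000 nM
- compound 2 `COc1cc(/C=C/C(=O)/C=C/c2nc3c(C)cccc3n2C)ccc1O`: 3000 nM
- compound 3 `COc1cc(/C=C/C(=O)/C=C/c2nc3c(C)c(C)ccc3n2C)ccc1O`: 31900 nM

Still to be measured: compound 4 `COc1ccc2c(c1)nc(/C=C/C(=O)/C=C/c1ccc(O)c(OC)c1)n2C`.

Compound 1 holds the middle place of the three numbers in this assay. Compound 4 carries methoxy in place of hydrogen on an aromatic carbon of the core of compound 1: methoxy in place of hydrogen on an aromatic carbon. Among the compounds with values here, no measured step involves methoxy. The closest evidence is two changes of methyl in place of hydrogen on an aromatic carbon. One is modest, a 2.3-fold lower number from compound 1 to compound 2 (0.37 log units; beyond the scatter), and the other is large and runs the opposite way, an 11-fold higher number from compound 2 to compound 3 (1.03 log units; beyond the scatter). With the two directions in conflict, no step beyond the scatter is expected in this assay. The expected change is a 1.1-fold higher number from compound 1 to compound 4 (0.06 log units; within the scatter), with wide uncertainty. For compound 4 the estimated value is 8000 nM, with an expected range of 2500 nM to 25000 nM.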

Compound 4, half-maximal inhibitory concentration: 12700 nM
Estimate against measurement, compound 4: 1.6-fold (0.20 log units) below; measured number inside the range.
By their numbers in this assay, from the lowest: compound 2; then compounds 1 and 4 (each within the scatter of the next); then compound 3.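

In this assay, within the data shown here, methoxy in place of hydrogen on an aromatic carbon of the core of compound 1 gives a 1.8-fold higher number from compound 1 to compound 4 (0.26 log units; within the scatter) as its only recorded step. This is the only step shown on this six-membered ring that stays within the scatter, whereas both methyl steps lie beyond it. No measurement available here accounts for this result. The compounds shown leave open whether an amine or a carboxylic acid at this position would also stay within the scatter. They also leave open whether a longer chain, such as ethoxy, would do so.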